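The source may report more compounds than this note shows. Statements on the series, on what has been measured and on what is new or still open speak of the compounds shown alone.

In an ADME assay on cells (Hepatocyte, Mus musculus) for metabolic stability, with a stated time of 30 min (a higher number here means that more of the compound is left, a lower number that less of the compound is left), compound 2 (`O=c1cc(N2CCN(CC3CCC(NS(=O)(=O)c4ccccc4)CC3)CC2)sc2c([N+](=O)[O-])cc(C(F)(F)F)cc12`) gives 95.3%, the higher of the two numbers at hand. Compound 1 (`O=C(OC1CCC(CN2CCN(c3cc(=O)c4cc(C(F)(F)F)cc([N+](=O)[O-])c4s3)CC2)CC1)c1ccccc1`) gives 68.1%. For the measured compounds named here, the only measured step is a number 27.2 percentage points higher from compound 1 to compound 2 (beyond the scatter), with (phenylsulfonyl)amino in place of benzoyloxy on a saturated ring carbon. Compound 3 (`O=C(OC1CCC(CN2CCN(c3cc(=O)c4cc(C(F)(F)F)cc([N+](=O)[O-])c4s3)CC2)CC1)c1ccncc1`) differs from compound 2 on that same carbon, with ((pyridin-4-yl)carbonyl)oxy in place of (phenylsulfonyl)amino on a saturated ring carbon. This change largely runs the measured step in reverse. Like compound 1, which gives 68.1%, compound 3 carries a carbonyloxy group at this place, and the two differ only in the aromatic ring, which in compound 3 has one hetero atom. No measurement shows what that ring exchange does on its own, so the range must stay wide. A fall beyond the scatter is therefore expected, of about the size of the measured step or somewhat larger. The expected change is a number 33.3 percentage points lower from compound 2 to compound 3 (beyond the scatter). The estimate for compound 3 is 62%, with an expected range from 38% to 85%.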

Compound 3, percent of the compound remaining: 1.4%
Estimate against measurement, compound 3: 60.6 percentage points above; the measured number lies below the stated range.
By their numbers in this assay, from the lowest: compound 3; then compound 1; then compound 2.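

In this assay, exchanging phenyl for pyridin-4-yl on the carbonyl carbon, with nothing else altered, gives a number 66.7 percentage points lower from compound 1 to compound 3 (beyond the scatter), so the aromatic ring on this carbonyloxy group weighs heavily at this position, which the earlier pair could not show. The carbonyloxy link alone therefore does not set the number, and the step of a number 93.9 percentage points lower from compound 2 to compound 3 (beyond the scatter) is much larger than the earlier a number 27.2 percentage points higher from compound 1 to compound 2 (beyond the scatter), which involved the same link and the same place on the saturated ring carbon. Nothing at hand tells why a single ring atom exchange has so large an effect here.

The compounds shown leave open whether pyridin-4-yl would have a similar effect on the sulfonylamino link of compound 2, and whether a pyridin-3-yl ring on the carbonyl carbon would behave like the pyridin-4-yl ring of compound 3. Going by these compounds, it also remains open how an amide link between the saturated ring carbon and the pyridin-4-yl ring, or a simple amine or carboxylic acid at that carbon, would fare in this assay.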